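A few compounds are considered here, and "the series" means these few. Any claim that something is new, unique, unknown or untested is made for them only; others in the source may bear on it.

Measured so far:
compound 1, `CCn1c(SCC(=O)c2ccccc2)nnc1-c1ccc(OC)cc1`: 60%
compound 2, `CCn1c(SCC(=O)c2ccccc2)nnc1-c1ccccc1`: 55%

Of the compounds shown here, two have been measured in a functional assay on the whole organism (strain albino) for inhibition, with Rattus norvegicus as the target, read by paw edema, with a stated time of 2 h, at a dose of 0.28 mmol/kg by the oral route; on this read-out lower numbers stand for less inhibition and higher numbers for more inhibition at the one dose given (going by the name of the read-out). Compound 1 gives 60%, the higher of the two numbers; its nearest neighbour is compound 2, and the step of a number 5 percentage points lower from compound 1 to compound 2 (within the scatter) does not separate the pair. Going by the values given here, that step replaces the methoxy on an aromatic carbon with hydrogen, and it is the only measured step.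

Compound 3, `COc1ccc(-c2nnc(SCC(=O)c3ccccc3)n2-c2ccccc2)cc1`, remains to be measured. Relative to compound 1 the change is phenyl in place of ethyl on an aromatic nitrogen. Among the compounds with values here, the one measured step, from compound 1 to compound 2, touches a different place, the aromatic carbon that carries the methoxy, and leaves the aromatic nitrogen untouched; it therefore gives no direct guide to phenyl in place of ethyl on that nitrogen. Within the data shown here, with no step bearing on the change, and the only available step being within the scatter, no movement beyond the scatter is expected in this assay, in either direction, though the range must stay wide. Compound 3 is expected to give 58%, between 40% and 75%, which means an expected step of a number 2 percentage points lower from compound 1 to compound 3 (within the scatter).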

Compound 3, a percentage reported as inhibition, in the whole organism at one dose (the size of the read-out at that dose, not a potency): 57%
The estimate for compound 3 lay 1 percentage points above the measured number; low and high end bracket the measured number.
By their numbers in this assay, from the lowest: compounds 2, 3 and 1 (each within the scatter of the next).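

In this assay the aromatic nitrogen of the five-membered ring now has a measured step of its own, with a number 3 percentage points lower from compound 1 to compound 3 (within the scatter) on putting phenyl in place of ethyl. Going by these compounds alone, the entering group has 6 heavy atoms against 2 for ethyl and brings one six-membered aromatic ring of carbon only, so this nitrogen, on the ring atom next to the one bearing the 4-methoxyphenyl group, carries the larger group with no movement beyond the scatter at the one dose given. No measurement at hand bears on why this exchange leaves the read-out within the scatter.

From the compounds shown here alone, whether a longer chain or a chain ending in an amine on this nitrogen would also stay within the scatter of compound 1 remains open, as does whether phenyl on this nitrogen behaves the same with hydrogen in place of methoxy on the aromatic carbon. Going by these compounds, the read-out gives the size of the effect at one dose and one time, so any difference in potency between compound 1 and compound 3 also stays open.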